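A few compounds are considered here, and "the series" means these few. Any claim that something is new, unique, unknown or untested is made for them only; others in the source may bear on it.

Three ureas of a shared core have been run in an ADME assay on the whole organism with Oryza sativa as the target, tested at 10 uM; a lower number here means a stronger effect, a higher number a weaker effect of the compound at the concentration tested. Compound 1 `C[C@H](NC(=O)Nc1ccc(C(C)(C)C)cc1)c1ccccc1` gives 64%. Compound 2 `CCCCCc1ccc(NC(=O)N[C@H](C)c2ccccc2)cc1` gives 97%. Compound 3 `CCCCCc1ccc(NC(=O)N[C@@H](C)c2ccccc2)cc1` differs from compound 2 only in the configuration as drawn, and compound 3 gives 93%. The step of a number 4 percentage points lower from compound 2 to compound 3 (within the scatter) lies within the scatter, which fits (the fact that compounds 2 and 3 differ only in the configuration as drawn). Within the data shown here, the step of a number 29 percentage points higher from compound 1 to compound 3 (beyond the scatter) lies beyond the scatter and is the only measured change at the aromatic carbon that carries the substituent. Among the measured compounds shown here, on the numbers so far compound 3 stands second highest of three, within the scatter of compound 2 and beyond the scatter from compound 1.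

Compound 4 `CC(=O)c1ccc(NC(=O)N[C@@H](C)c2ccccc2)cc1` is the next member of the series. The change from compound 3 is acetyl in place of pentyl on an aromatic carbon. For the measured compounds named here, no measured step covers acetyl at this aromatic carbon; the one step there, a number 29 percentage points higher from compound 1 to compound 3 (beyond the scatter), moved the read-out modestly when tert-butyl became pentyl, so replacing pentyl by a group of a different kind is expected to move it by a comparable or somewhat larger amount, downward. The estimate for compound 4 in this assay is 65%, with a range from 40% to 92%. The expected step is then a number 28 percentage points lower from compound 3 to compound 4 (beyond the scatter).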

Compound 4, a percentage reported as activity, at one concentration (the size of the read-out at that concentration, not a potency): 96%
Beside the measured number, compound 4's estimate is 31 percentage points below it, outside the stated range (above it).
By their numbers in this assay, from the lowest: compound 1; then compounds 3, 4 and 2 (each within the scatter of the next).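

In this assay, the aromatic carbon para to a large group accepts two very different substituents with no readable change: a number 3 percentage points higher from compound 3 to compound 4 (within the scatter). Acetyl is smaller than pentyl by heavy-atom count and brings an oxygen, a double bond outside the aromatic ring and a hydrogen-bond acceptor, yet these differences leave no mark on the read-out, while a number 32 percentage points higher from compound 1 to compound 4 (beyond the scatter) shows that tert-butyl, with compound 1 at 64%, now stands apart from two different groups rather than from pentyl alone. The compounds at hand give no measured property that accounts for tert-butyl standing apart or for acetyl and pentyl reading alike.

Going by these compounds, it remains open whether the lower number belongs to tert-butyl alone, or whether isopropyl, cyclohexyl, an amine or a carboxylic acid at this aromatic carbon would read with compound 1 or with compounds 3 and 4. On these data alone, it is equally open whether acetyl paired with the configuration drawn in compound 2 would read with compound 4, as pentyl did across that same stereocentre.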